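The compounds below may be only part of what the source reports. "The series", "measured", "known", "first", "only" and "open" are said of these compounds alone.

Three compounds share the same core and are compared in an assay for binding affinity to Alpha-1A adrenergic receptor (Homo sapiens), read by radioligand binding; on this read-out lower numbers stand for stronger inhibition and higher numbers for weaker inhibition. Compound 1, with the structure `CSc1c(F)cccc1NCC1=NCCN1`, gives 148 nM in this assay. Compound 2, with the structure `CS(=O)(=O)c1ccc(Cl)cc1NCC1=NCCN1`, gives 537 nM in this assay. Compound 3, with the structure `CSc1ccc(Cl)cc1NCC1=NCCN1`, gives 18.6 nM in this assay, the lowest number of the three. The difference between the core of compound 1 and that of compound 3 is not broken down here; their two values simply show compound 3 standing lower.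

One single-point change is measured: from compound 3 to compound 2 the structures differ in this way (methylsulfonyl in place of methylsulfanyl on an aromatic carbon), and it carries a step of a 29-fold higher number from compound 3 to compound 2 (1.46 log units; beyond the scatter), a large one.

Compound 4, with the structure `CS(=O)(=O)c1c(F)cccc1NCC1=NCCN1`, has not yet been measured in this assay. It differs from compound 1 in this way (methylsulfonyl in place of methylsulfanyl on an aromatic carbon). This is the same kind of change as that from compound 3 to compound 2, though the surroundings differ: in compound 2 the changed carbon is para to a chloro group, whereas in compound 4 it is ortho to a fluoro group. For the measured compounds named here, the change from compound 1 to compound 4 is expected to bring a step of about a 20-fold higher number from compound 1 to compound 4 (1.31 log units; beyond the scatter), resting on the single measured example of this change, because of a 29-fold higher number from compound 3 to compound 2 (1.46 log units; beyond the scatter), and tempered by the different surroundings. Compound 4 is therefore estimated to give roughly 3000 nM in this assay, likely between 800 nM and 12000 nM.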

Compound 4, inhibition constant: 550 nM
Compound 4: middle estimate off by 5.5-fold (0.74 log units), on the high side; measured number below the stated range.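

In this assay, methylsulfonyl in place of methylsulfanyl on an aromatic carbon again gives a higher number, here a step of a 3.7-fold higher number from compound 1 to compound 4 (0.57 log units; beyond the scatter). Set beside the earlier case, the direction of the change carries from one core to the other, but its size does not: the same change on two cores in this assay, a 29-fold higher number (1.46 log units; beyond the scatter) from compound 3 to compound 2 and a 3.7-fold higher number (0.57 log units; beyond the scatter) from compound 1 to compound 4, 7.8-fold (0.89 log units) apart, beyond the scatter of two such steps With only two examples, this shows that a step measured on one core cannot be taken over at full size to another in this series, but it does not show which difference between the cores sets the size, nor how large the step would be on any further core.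

The compounds shown leave open how the same change behaves with other halogens or groups on the ring, such as a bromo or a methoxy group, so the part played by the fluoro and chloro groups cannot be separated from the rest of each core. They also leave open how methylsulfinyl, a longer chain such as ethylsulfanyl, or an amine on the same aromatic carbon would stand against methylsulfanyl and methylsulfonyl on either core.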